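The compounds below may be only part of what the source reports. "The series", "measured", "known", "first", "only" and "open" are said of these compounds alone.

Measured compounds:

Compound 1 `O=c1cc(-c2ccccc2)oc2cc(OCCCCNc3nc4ccc(Cl)cc4s3)cc(O)c12`: 12.4 ug/mL
Compound 2 `O=c1cc(-c2ccccc2)oc2cc(OCCCCNc3nc4ccc(I)cc4s3)cc(O)c12`: 13.2 ug/mL
Compound 3 `O=c1cc(-c2ccccc2)oc2cc(OCCCCNc3nc4ccc(F)cc4s3)cc(O)c12`: 13.4 ug/mL

In a functional assay on Ca-Ski cells (Homo sapiens) for cytotoxicity, read by sulforhodamine B assay, with a stated time of 48 h (on this read-out higher numbers stand for weaker inhibition and lower numbers for stronger inhibition), compound 3 gives the highest of the three numbers, but the gaps to the other two are small: a 1.1-fold higher number from compound 1 to compound 3 (0.03 log units; within the scatter) and a 1.0-fold higher number from compound 2 to compound 3 (0.01 log units; within the scatter). On these data compound 3 cannot be called weaker than compound 1 or compound 2; the three sit together.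

Compound 4 `O=c1cc(-c2ccccc2)oc2cc(OCCCCNc3nc4ccc(C(F)(F)F)cc4s3)cc(O)c12` has not yet been measured in this assay. Its change from compound 3 is trifluoromethyl in place of fluoro on an aromatic carbon. The measured steps that bear on it are the three halogen swaps on this same aromatic carbon: a 1.1-fold higher number from compound 1 to compound 2 (0.03 log units; within the scatter), a 1.1-fold higher number from compound 1 to compound 3 (0.03 log units; within the scatter) and a 1.0-fold higher number from compound 2 to compound 3 (0.01 log units; within the scatter), each within the scatter. None of them puts a trifluoromethyl group there, so the new group is not covered directly, yet the ring position has so far tolerated three different halogens without a shift beyond the scatter. For compound 4 the expected step is therefore a 1.0-fold lower number from compound 3 to compound 4 (0.01 log units; within the scatter), that is, no movement beyond the scatter. Compound 4 is estimated at 13 ug/mL, with a range from 6.5 ug/mL to 26 ug/mL.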

Compound 4, half-maximal inhibitory concentration: 11.2 ug/mL
Beside the measured number, compound 4's estimate is 1.2-fold (0.06 log units) above it, within the range that was stated.
By their numbers in this assay, from the lowest: compounds 4, 1, 2 and 3 (each within the scatter of the next).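

In this assay, this aromatic carbon also accepts trifluoromethyl, with its 4 heavy atoms in place of the 1 of fluoro, so tolerance here is not limited to single halogen atoms. The new group gives a 1.2-fold lower number from compound 3 to compound 4 (0.08 log units; within the scatter) and a 1.2-fold lower number from compound 2 to compound 4 (0.07 log units; within the scatter) and also a 1.1-fold lower number from compound 1 to compound 4 (0.04 log units; within the scatter), so all four compounds sit together and none can be ranked above another. No measured property of these groups is available to account for this flat picture.

On these data alone, all four compounds carry a halogen or trifluoromethyl at this position, so it remains open whether an amine or a carboxylic acid there would move the number beyond the scatter. As far as these compounds go, it is also open whether a longer chain, in place of the one shared by all four, would change the result.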